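The source may report more compounds than this note shows. Statements on the series, on what has been measured and on what is new or still open speak of the compounds shown alone.

Measured in a functional assay on ZR-75-1 cells (Homo sapiens) for inhibition, read by sulforhodamine B assay; a higher number here means a weaker inhibitor of growth, a lower number a stronger inhibitor of growth:
- compound 1 `Oc1cccc2[nH]c(-c3ccc(-c4ccc(-c5ccccc5)cc4)cc3)nc12`: 35600 nM
- compound 2 `Oc1cccc2[nH]c(-c3ccc(-c4ccc(-c5ccc(OC(F)(F)F)cc5)cc4)cc3)nc12`: 3800 nM
- compound 3 `Oc1ccc(-c2ccc(-c3ccc(-c4nc5c(O)cccc5[nH]4)cc3)cc2)cc1`: 2650 nM

Compound 3 stands well clear of compound 1, a 13-fold lower number from compound 1 to compound 3 (1.13 log units; beyond the scatter), and level with compound 2 within the scatter, a 1.4-fold lower number from compound 2 to compound 3 (0.16 log units; within the scatter). Compound 4 `COc1ccc(-c2ccc(-c3ccc(-c4nc5c(O)cccc5[nH]4)cc3)cc2)cc1` differs from compound 3 by methyl in place of hydrogen on an oxygen on an aromatic ring, which turns hydroxy to methoxy. Two measured steps add a group to the unsubstituted end: a 9.4-fold lower number from compound 1 to compound 2 (0.97 log units; beyond the scatter) and a 13-fold lower number from compound 1 to compound 3 (1.13 log units; beyond the scatter). The closest guide is the change on that oxygen, where trifluoromethyl and hydrogen gave a 1.4-fold lower number from compound 2 to compound 3 (0.16 log units; within the scatter). Methyl on the same oxygen is therefore expected to bring no step beyond the scatter in this assay. The estimated step is a 1.3-fold higher number from compound 3 to compound 4 (0.12 log units; within the scatter). For compound 4 the expected value is 3500 nM, with an estimated range of 1400 nM to 9000 nM.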

Compound 4, concentration for 50% growth inhibition: 8200 nM
For compound 4 the middle estimate is 2.3-fold (0.37 log units) below the measured one; low and high end bracket the measured number.
By their numbers in this assay, from the lowest: compounds 3 and 2 (each within the scatter of the next); then compound 4; then compound 1.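

In this assay, methyl on this oxygen gives a weaker inhibitor of growth (a 3.1-fold higher number from compound 3 to compound 4 (0.49 log units; beyond the scatter)), so the oxygen is not indifferent to its substituent, although hydrogen and trifluoromethyl there stayed level within the scatter. Methyl also falls short of trifluoromethyl (a 2.2-fold higher number from compound 2 to compound 4 (0.33 log units; beyond the scatter)), yet methoxy keeps a gain over the unsubstituted end (a 4.3-fold lower number from compound 1 to compound 4 (0.64 log units; beyond the scatter)). Nothing available explains why methyl parts from the other two groups on this oxygen. The compounds shown leave open how ethyl or a longer chain on this oxygen would behave. They also leave open whether an amine or a carboxylic acid could replace the hydroxy.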